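Thiophene-methyl amide series: oxazolyl in place of pyrimidinyl

The source may report more compounds than this note shows. Statements on the series, on what has been measured and on what is new or still open speak of the compounds shown alone.

Three compounds of this series have numbers in an assay on HEK293 cells for agonist activity at transient receptor potential cation channel subfamily M member 8 (Homo sapiens), read by fluorescence and calcium flux, with a stated time of 15 min; a lower number here means that less compound is needed, a higher number that more compound is needed for the effect. Compound 1 `CCN(Cc1ccc(C)s1)C(=O)COc1ccc(C)cc1` gives 178 nM in this assay. Compound 3 `CCN(Cc1cccs1)C(=O)COc1ccccc1` gives 1400 nM. Compound 2 `Cc1ccc(OCC(=O)N(Cc2cccs2)c2ncccn2)cc1` gives 3700 nM, the highest number of the three; its gap to compound 3 is the smaller one and its gap to compound 1 the larger, and both lie beyond the scatter of this assay. Compound 1 and compound 3 carry an ethyl group on the amide-type nitrogen, whereas compound 2 carries an aromatic ring there.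

Compound 4 `Cc1ccc(OCC(=O)N(Cc2cccs2)c2ncco2)cc1` is not yet measured. It differs from compound 2 in one place: 1,3-oxazol-2-yl in place of pyrimidin-2-yl on an amide-type nitrogen. Among the compounds with values here, no measured pair shows the effect of exchanging one aromatic ring for another on this nitrogen, so no step can be carried over. Given that compound 2 gives 3700 nM with a six-membered aromatic ring at this position, the expected step of a 1.2-fold lower number from compound 2 to compound 4 (0.09 log units; within the scatter) is estimated to be small, in either direction, and not clearly beyond the scatter. Compound 4 is therefore expected to give about 3000 nM in this assay, within a range of 800 nM to 12000 nM.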

Compound 4, half-maximal effective concentration: 0.3 nM
Compound 4: middle estimate off by 10000-fold (4.00 log units), on the high side, and the stated range ends above it.
By their numbers in this assay, from the lowest: compound 4; then compound 1; then compound 3; then compound 2.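

Within the data shown here, the position on the amide-type nitrogen proves far more sensitive than the earlier compounds could show, since none of them formed a pair that exchanged one aromatic ring for another here. In this assay, compound 4 gives 0.3 nM, and the exchange of pyrimidin-2-yl for 1,3-oxazol-2-yl amounts to a 12000-fold lower number from compound 2 to compound 4 (4.09 log units; beyond the scatter), even though the counts of hydrogen-bond donors and acceptors stay the same, neither group carries a net charge, and the heavy-atom count changes only from 6 to 5. No measurement available here bears on the origin of this step, so it stands as an observation without an explanation.

Among these compounds, the single pair does not separate the change from a six-membered to a five-membered aromatic ring from the entry of the ring oxygen, and 1,3-thiazol-2-yl, with sulfur in place of that oxygen, or pyridin-2-yl, with one ring nitrogen instead of two, would divide these two changes. Also open, from the compounds shown here alone, is whether the step holds on other versions of the shared core, such as one with a methyl group on the thiophene or without the methyl group on the phenoxy ring.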